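The source may hold more compounds than are shown below. What is called first, only, known or untested is meant among the compounds shown, and "the series" means these compounds.

Two analogues of the shared core have been measured so far. Compound 1 `COc1ccc(/C=C/C(=O)c2ccc(OC)c3c2OC(C)(C)C=C3)cc1OCCCN(C)C` carries 3-(dimethylamino)propyl on an oxygen on an aromatic ring, and in a functional assay on HepG2 cells (Homo sapiens) for cytotoxicity, read by MTT assay (on this read-out higher numbers stand for weaker inhibition and lower numbers for stronger inhibition), compound 1 gives 5550 nM. Among the measured compounds shown here, compound 2 `COc1ccc(/C=C/C(=O)c2ccc(OC)c3c2OC(C)(C)C=C3)cc1OC(=O)C1CC1` carries cyclopropylcarbonyl on that oxygen; in this assay compound 2 gives 220 nM, the lowest of the two numbers, and the single measured step, a 25-fold lower number from compound 1 to compound 2 (1.40 log units; beyond the scatter), is large. For the measured compounds named here, compound 3 `COc1ccc(/C=C/C(=O)c2ccc(OC)c3c2OC(C)(C)C=C3)cc1OS(=O)(=O)c1ccc(C)cc1` awaits measurement. (4-methylphenyl)sulfonyl in place of cyclopropylcarbonyl on an oxygen on an aromatic ring Only one measured step touches this oxygen, a 25-fold lower number from compound 1 to compound 2 (1.40 log units; beyond the scatter); it shows that exchange there can move the number far, but it contains neither group now in play, so its direction cannot be carried over. Without a closer precedent, compound 3 is expected to sit close to compound 2, with a 1.8-fold higher number from compound 2 to compound 3 (0.26 log units; within the scatter) expected to fall within the scatter. The estimate for compound 3 is 400 nM, with a range from 120 nM to 1500 nM.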

Compound 3, half-maximal inhibitory concentration: 3600 nM
For compound 3 the middle estimate is 9.0-fold (0.95 log units) below the measured one; the whole stated range lies below it.
By their numbers in this assay, from the lowest: compound 2; then compounds 3 and 1 (each within the scatter of the next).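

In this assay, (4-methylphenyl)sulfonyl in place of cyclopropylcarbonyl on an oxygen on an aromatic ring gives a 16-fold higher number from compound 2 to compound 3 (1.21 log units; beyond the scatter), so the low number of compound 2 does not carry over to compound 3. The step of a 1.5-fold lower number from compound 1 to compound 3 (0.19 log units; within the scatter) leaves 3-(dimethylamino)propyl and (4-methylphenyl)sulfonyl unseparated in spite of their different make-up, and among these three compounds only cyclopropylcarbonyl stands apart. Nothing at hand bears on why this group stands apart.

As far as these compounds go, whether the low number belongs to cyclopropylcarbonyl alone or extends to other carbonyl groups, such as acetyl or benzoyl, remains open. The compounds shown also leave open how a free hydroxyl or a methanesulfonyl group on that oxygen would compare.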